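A few compounds are considered here, and "the series" means these few. Any claim that something is new, unique, unknown or untested is made for them only; others in the source may bear on it.

In a functional assay on CAL-27 cells (Homo sapiens) for cytotoxicity, read by MTT assay, with a stated time of 72 h (a higher number here means a weaker inhibitor, a lower number a stronger inhibitor), compound 1 `Nc1ccccc1NC(=O)CCCCCN(CC(=O)NCc1ccccc1)C(=O)c1cccc2ccccc12` gives 11000 nM, compound 3 `Cc1ccc(CNC(=O)CN(CCCCCC(=O)Nc2ccccc2N)C(=O)c2cc(C)cc(C)c2)cc1` gives 18200 nM, and compound 2 `Nc1ccccc1NC(=O)CCCCCN(CC(=O)NC1CCCCC1)C(=O)c1cccc2ccccc12` gives 24900 nM. Compound 1 and compound 3 lie within the scatter of each other, at the low end of these numbers. Among the measured compounds shown here, the one measured step, a 2.3-fold higher number from compound 1 to compound 2 (0.35 log units; beyond the scatter), is modest and swaps benzyl for cyclohexyl on an amide-type nitrogen. Compound 4 `CN(C)c1ccc(C(=O)N(CCCCCC(=O)Nc2ccccc2N)CC(=O)NCc2ccccc2)cc1` keeps that benzyl and instead places 4-(dimethylamino)phenyl where naphthalen-1-yl sat on a carbonyl carbon: 4-(dimethylamino)phenyl in place of naphthalen-1-yl on a carbonyl carbon. For the measured compounds named here, no measured step covers this exact change, so the modest step above serves only as a rough guide to size in this assay. The expected step, a 1.3-fold higher number from compound 1 to compound 4 (0.10 log units; within the scatter), is estimated to stay within the scatter, with no firm direction. For compound 4 the estimated value is 14000 nM, with an expected range of 6000 nM to 30000 nM.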

Compound 4, half-maximal inhibitory concentration: 16000 nM
Estimate against measurement, compound 4: 1.1-fold (0.06 log units) below; the measured number falls inside the stated range.
By their numbers in this assay, from the lowest: compounds 1, 4, 3 and 2 (each within the scatter of the next, the first and the last beyond it).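

At this position, on a carbonyl carbon, the two-ring naphthalen-1-yl and the one-ring 4-(dimethylamino)phenyl, which adds a nitrogen and a hydrogen-bond acceptor, give a 1.5-fold higher number from compound 1 to compound 4 (0.16 log units; within the scatter) in this assay. With the benzyl kept, this change therefore leaves no difference that can be read beyond the scatter. No evidence here bears on why.

Still open, as far as these compounds go, is how a carboxylic acid or a morpholine ring on that phenyl would read, and whether a plain phenyl would match these two compounds.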